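The source may hold more compounds than are shown below. What is called first, only, known or untested is meant among the compounds shown, and "the series" means these compounds.

In a functional assay on THP-1 cells (Homo sapiens) for cytotoxicity, read by MTT assay, with a stated time of 24 h (on this read-out higher numbers stand for weaker inhibition and lower numbers for stronger inhibition), compound 1 (`CN1C/C(=C\c2cccc([N+](=O)[O-])c2)C(=O)/C(=C/c2ccccc2F)C1`) gives 1010 nM and compound 2 (`CN1C/C(=C\c2ccc(C#N)cc2)C(=O)/C(=C/c2ccccc2F)C1`) gives 810 nM while compound 3 (`COc1cc(/C=C2\CN(C)C/C(=C\c3ccc(Br)cc3)C2=O)cc(OC)c1`) gives 4270 nM as the highest of the three, beyond the scatter from both others. Compound 4 (`COc1cc(/C=C2\CN(C)C/C(=C\c3ccc(C#N)cc3)C2=O)cc(OC)c1`) departs from compound 3 in one place, with cyano in place of bromo on an aromatic carbon. Among the compounds with values here, no measured pair shows this change alone. Compound 3 differs from compound 2 in more than this one place, yet compound 2, which carries the 4-cyanophenyl, stands at 810 nM and so points towards a lower number. A modest move towards stronger inhibition is therefore expected in this assay as an estimated 2.2-fold lower number from compound 3 to compound 4 (0.35 log units; beyond the scatter) near the edge of the scatter. Compound 4 is estimated at 1900 nM with an expected range from 750 nM to 4800 nM for its measurement.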

Compound 4, half-maximal inhibitory concentration: 940 nM
Estimate against measurement, compound 4: 2.0-fold (0.31 log units) above; the measured number falls inside the stated range.
By their numbers in this assay, from the lowest: compounds 2, 4 and 1 (each within the scatter of the next); then compound 3.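

In this assay, within the data shown here, the change from 4-bromophenyl to 4-cyanophenyl gives a 4.5-fold lower number from compound 3 to compound 4 (0.66 log units; beyond the scatter) and is the first step here in which only one place differs, showing that the group on this aromatic carbon bears on the read-out when the rest of compound 3 stays fixed. Nothing measured here accounts for the size of this step. On these data alone, whether an amine or a carboxylic acid on this carbon would move the number further, in either direction, stays open. So does whether cyano in place of bromo gives a similar step with other groups on the far side of the core.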